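Aryl amide replaces methylamide where all values sit at limit

A few compounds are considered here, and "the series" means these few. Any claim that something is new, unique, unknown or untested is made for them only; others in the source may bear on it.

Compound 1 `NC(=O)c1ccc2c(c1)nc(Nc1ccc(S(N)(=O)=O)cc1)n2Cc1ccccn1` in an assay on isolated protein for inhibition of kinesin heavy chain isoform 5A (Homo sapiens) (on this read-out higher numbers stand for weaker inhibition and lower numbers for stronger inhibition), gives > 50000 nM.
Compound 2 `COC(=O)c1ccc2c(c1)nc(Nc1ccc(S(N)(=O)=O)cc1)n2Cc1ccccc1C(F)(F)F` in this assay gives > 50000 nM.
Compound 3 `CNC(=O)c1ccc2c(c1)nc(Nc1ccc(S(N)(=O)=O)cc1)n2Cc1ccccc1C(F)(F)F` in this assay gives > 50000 nM.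

For the measured compounds named here, the value of compound 3 is a limit of the assay, not a number. the limit of > 50000 nM in this assay, at which 3 of the 3 values shown sit, shows that compound 1 and compound 2 sit at the same limit, so the only single-point step, a step that the two limits leave unreadable from compound 2 to compound 3, cannot be read. Compound 4 `COc1ccccc1NC(=O)c1ccc2c(c1)nc(Nc1ccc(S(N)(=O)=O)cc1)n2Cc1ccccc1C(F)(F)F` differs from compound 3 by 2-methoxyphenyl in place of methyl on an amide-type nitrogen. Going by the values given here, no measured step bears on a change of this kind, and the one step available is unreadable. With compound 3 unmeasurable, the step of an at least 1.2-fold lower number from compound 3 to compound 4 (0.09 log units; that floor lies within the scatter) is expected to stay unreadable. Compound 4 is therefore estimated at 40000 nM, within 5000 nM to 150000 nM.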

Compound 4, half-maximal inhibitory concentration: > 50000 nM
Compound 4 gave a limit, no number; the forecaster's own chance of this, stated with the estimate: 70%; middle value at least 1.2-fold (0.09 log units) from the limit.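

Compound 4 gives > 50000 nM in this assay, which is a limit of the assay. The steps to compound 4 from compound 2 and compound 3 therefore cannot be read: the limit of > 50000 nM in this assay, at which 4 of the 4 values shown sit.

The compounds shown leave open which change to the shared core, if any, would give a measurable number in this assay.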